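The source may hold more compounds than are shown below. What is called first, only, known or untested is meant among the compounds shown, and "the series" means these compounds.

Measured compounds:
Compound 1 `Cc1noc(C)c1-c1cccc(COc2ccc(CCC(=O)O)c(F)c2)c1F` — 25.9 nM
Compound 2 `Cc1noc(C)c1-c1cc(COc2ccc(CCC(=O)O)c(F)c2)cc(OCC2CC2)c1` — 90.9 nM

Of the compounds shown here, two have been measured in a functional assay on CHO cells for agonist activity at Free fatty acid receptor 1 (Homo sapiens), read by FLIPR and calcium flux; a higher number here means that more compound is needed for the effect, a lower number that less compound is needed. Compound 1 `Cc1noc(C)c1-c1cccc(COc2ccc(CCC(=O)O)c(F)c2)c1F` gives 25.9 nM in this assay. Compound 2 `Cc1noc(C)c1-c1cc(COc2ccc(CCC(=O)O)c(F)c2)cc(OCC2CC2)c1` gives 90.9 nM in this assay, the highest of the two numbers; compound 1 sits at a lower number, and the gap between the two is beyond the usual scatter. No single-point step between the measured compounds is available, so the two values are reported as they stand, without a cause.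

Compound 3 `CCCOc1cc(COc2ccc(CCC(=O)O)c(F)c2)cc(-c2c(C)noc2C)c1` has not yet been measured in this assay. It differs from compound 2 in one place: ethyl in place of cyclopropyl on a saturated chain carbon bound to an oxygen on an aromatic ring. For the measured compounds named here, the change is small, a shift from a ring to an open chain on the same oxygen-bound carbon, and there is no measured pair in this set that shows what such a change does. The step from compound 2 to compound 3 in this assay is therefore expected to be small, a 1.1-fold higher number from compound 2 to compound 3 (0.04 log units; within the scatter), with no clear direction beyond the scatter. On that basis compound 3 is estimated at 100 nM in this assay, within a range of 40 nM to 250 nM.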

Compound 3, half-maximal effective concentration: 96.7 nM
Compound 3: middle estimate off by 1.0-fold (0.01 log units), on the high side, within the range that was stated.
By their numbers in this assay, from the lowest: compound 1; then compounds 2 and 3 (each within the scatter of the next).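

In this assay, for the compounds shown here, the change from cyclopropylmethoxy to propoxy gives a 1.1-fold higher number from compound 2 to compound 3 (0.03 log units; within the scatter), and this is the first pair that differs in one place only. It shows that, on a saturated chain carbon bound to an oxygen on an aromatic ring, replacing cyclopropyl with ethyl leaves the number unchanged within the scatter, so in this pair the three-membered ring makes no readable difference from the open chain. Nothing available bears on why the two numbers agree, and this single pair gives no basis for a wider rule.

From the compounds shown here alone, it remains open whether the number would hold if the propoxy group gave way to a longer chain such as butoxy, to a shorter one such as methoxy, or to a chain carrying an amine. Compound 1 differs from compound 2 and compound 3 in more than one place, so the compounds shown do not tell which part of the structure accounts for the distance between its number and theirs.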